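Replacing an amino group with a cyanotriazolyl group

The source may report more compounds than this note shows. Statements on the series, on what has been measured and on what is new or still open speak of the compounds shown alone.

Compound 3 `CNc1nc(N)nc(NC2(C#N)CCCCC2)n1` has no single number in an in vitro assay on Sf21 cells for inhibition of high affinity 3',5'-cyclic-AMP phosphodiesterase 7A (Homo sapiens); a higher number here means a weaker inhibitor, a lower number a stronger inhibitor: in this assay compound 3 gives "not determined" (no result reported). Compound 1 `CNc1nc(NC2(C#N)CCCCC2)nc(N(C)C)n1` in this assay gives > 5000 nM, which is a limit of the assay. Compound 2 `CNc1nc(NC2(C#N)CCCCC2)nc(N2CCCC2)n1` in this assay gives > 5000 nM, also a limit. The step that the two limits leave unreadable from compound 1 to compound 2 therefore cannot be read, since the limit of > 5000 nM in this assay, at which 2 of the 3 values shown sit, holds both ends. Among the measured compounds shown here, compound 4 `CNc1nc(NC2(C#N)CCCCC2)nc(-n2cnc(C#N)n2)n1` differs from compound 3 by 3-cyano-1H-1,2,4-triazol-1-yl in place of amino on an aromatic carbon, a change on the shared core that no measured pair mirrors, so no step bears directly on it. With both neighbours sitting at the limit and compound 3 without a number, no direction beyond the scatter can be expected for this change. Compound 4 is expected to sit near the limit in this assay, with an estimate of 8000 nM and a range from 1500 nM to 40000 nM.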

Compound 4, half-maximal inhibitory concentration: > 5000 nM
Compound 4: no number, only a limit; the forecaster's own chance of this, stated with the estimate: 60%; the middle value does not contradict the limit.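

The steps from compound 1 and from compound 2 to compound 4 cannot be read, since all three compounds sit at the same limit: the limit of > 5000 nM in this assay, at which 3 of the 4 values shown sit. The compounds shown leave open how dimethylamino, pyrrolidin-1-yl and 3-cyano-1H-1,2,4-triazol-1-yl compare on the shared core, as none of the three compounds carrying them has a number.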